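This account rests on a few compounds, and the source may have more. Where it says the series, first, only, none or still open, it means among the compounds named here.

Measured in a functional assay on MiaPaCa cells (Homo sapiens) for antiproliferative activity, read by sulforhodamine B assay, with a stated time of 48 h; a lower number here means a stronger inhibitor of growth, a higher number a weaker inhibitor of growth:
- compound 1 `Cc1ccc(-c2cn(CCCN3C(=O)COc4ccccc43)nn2)cc1`: > 100000 nM. This value is a limit of the assay and not a number.
- compound 2 `CCCCCCc1cn(CCCN2C(=O)COc3ccccc32)nn1`: 150 nM
- compound 3 `CCCc1cn(CCCN2C(=O)COc3ccccc32)nn1`: 2600 nM

Of the two true numbers in this assay, compound 3 holds the higher, at 2600 nM. Going by the values given here, its only numerical neighbour is compound 2, and the gap is a 17-fold higher number from compound 2 to compound 3 (1.24 log units; beyond the scatter).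

Compound 4 `O=C1COc2ccccc2N1CCCn1cc(C2(O)CCCCC2)nn1` carries 1-hydroxycyclohexyl in place of propyl on an aromatic carbon of the five-membered aromatic ring with 3 nitrogen: 1-hydroxycyclohexyl in place of propyl on an aromatic carbon.

All measured steps change the group on this same carbon, and all are large: an at least 660-fold lower number from compound 1 to compound 2 (2.82 log units; beyond the scatter), an at least 38-fold lower number from compound 1 to compound 3 (1.58 log units; beyond the scatter) and the step between the two alkyl compounds given above. They point in two directions. The longer chain of compound 2 gives the lower number, while the aromatic ring of compound 1 gives only a limit. Among the compounds with values here, the entering group is a ring, but a non-aromatic one, and no measured compound has such a ring or a hydroxy-bearing group here. A moderate move to a higher number is therefore expected, with wide uncertainty: a 1.5-fold higher number from compound 3 to compound 4 (0.19 log units; within the scatter).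

For compound 4 the estimated value is 4000 nM, with an expected range of 600 nM to 30000 nM.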

Compound 4, concentration for 50% growth inhibition: 2500 nM
Compound 4: middle estimate off by 1.6-fold (0.20 log units), on the high side; measured number inside the range.
By their numbers in this assay, from the lowest: compound 2; then compounds 4 and 3 (each within the scatter of the next). At a limit, above all of these: compound 1.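

In this assay, propyl and 1-hydroxycyclohexyl cannot be told apart on this aromatic carbon: a 1.0-fold lower number from compound 3 to compound 4 (0.02 log units; within the scatter). The larger entering group, with its non-aromatic ring and hydroxy group, thus gives a result level with the short alkyl chain, while the hexyl of compound 2 remains clearly lower, with a 17-fold higher number from compound 2 to compound 4 (1.22 log units; beyond the scatter). Compound 1 stands at a limit of the assay and not at a number, so its comparison gives only a bound, an at least 40-fold lower number from compound 1 to compound 4 (1.60 log units; beyond the scatter), which shows that a ring on this carbon does not by itself bring the loss seen with 4-methylphenyl: the limit of > 100000 nM in this assay, at which 1 of the 4 values shown sits.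

On these data alone, the separate contributions of the ring and the hydroxy group stay open; plain cyclohexyl and a hydroxy-bearing open chain such as 6-hydroxyhexyl would separate them. Also open, as far as these compounds go, are whether the gain with chain length continues to an octyl or decyl chain, and where an amine or a carboxylic acid on this carbon would fall.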